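A few compounds are considered here, and "the series" means these few. Any claim that something is new, unique, unknown or untested is made for them only; others in the source may bear on it.

Measured compounds:
- compound 1, `O=C(Nc1ccccc1)c1cccc(Br)c1`: > 100000 nM
- compound 2, `O=C(Nc1ccc(Sc2nc3ccccc3s2)c(Cl)c1)c1cc(Br)cc(Br)c1`: > 100000 nM

In an assay on isolated protein for inhibition of thiosulfate sulfurtransferase (Homo sapiens), with a stated time of 60 min, in the absence of a further agent (a higher number here means a weaker inhibitor, a lower number a stronger inhibitor), compound 1 gives > 100000 nM, which is a limit of the assay and not a number. In this assay compound 2 gives > 100000 nM, again a limit and not a number. Among the measured compounds shown here, compound 2 therefore stands at the edge of what the assay reports, as does the only other value shown; both sit at the limit of > 100000 nM in this assay, at which 2 of the 2 values shown sit. For the measured compounds named here, no step between measured compounds is available.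

Compound 3, `O=C(Nc1ccc(Sc2nc3ccccc3s2)cc1)c1cc(Br)cc(Br)c1`, is not yet measured. It differs from compound 2 by hydrogen in place of chloro on an aromatic carbon.

Going by the values given here, with both known values at the limit there is no measured step to lean on. The expected step from compound 2 to compound 3 is none beyond the usual scatter, a step that the limit leaves unreadable from compound 2 to compound 3, so compound 3 is estimated at 150000 nM, within 50000 nM to 500000 nM, most likely reported again as a limit.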

Compound 3, half-maximal inhibitory concentration: > 100000 nM
Compound 3: a limit, no number; the forecaster's own chance of this, stated with the estimate: 85%; the middle value is on the limit's open side.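

In this assay, no step between compound 2 and compound 3 can be read, because both values are limits and not numbers: the limit of > 100000 nM in this assay, at which 3 of the 3 values shown sit.

The compounds shown leave open whether chloro or hydrogen on that aromatic carbon makes any difference to inhibition, and what structure would give a measurable value.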